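A benzyl group enters the core of compound 1

A few compounds are considered here, and "the series" means these few. Any claim that something is new, unique, unknown or untested is made for them only; others in the source may bear on it.

Going by the values given here, compound 1 `O/N=C(/Nc1ccccc1)c1ccc2occc2c1` gives the only number in an assay on tissue (HeLa cells) for inhibition of Indoleamine 2,3-dioxygenase 1 (Homo sapiens), read by spectrophotometry (a higher number here means a weaker inhibitor, a lower number a stronger inhibitor), namely 19000 nM. Compound 2 `O/N=C(/Nc1ccc(Cl)cc1)c1ccc2occc2c1` reaches only the limit of the assay, > 30000 nM. Compound 3 `Cc1ccc(N/C(=N/O)c2ccc3occc3c2)cc1C` likewise stops at the limit, > 30000 nM. Among the compounds with values here, the one measured step, an at least 1.5-fold higher number from compound 1 to compound 2 (0.19 log units; that floor lies within the scatter), is therefore only a floor, since the limit of > 30000 nM in this assay, at which 2 of the 3 values shown sit, caps what it can show. Compound 4 `O/N=C(/Nc1cccc(Cc2ccccc2)c1)c1ccc2occc2c1` differs from compound 1 by benzyl in place of hydrogen on an aromatic carbon. On these data alone, because an at least 1.5-fold higher number from compound 1 to compound 2 (0.19 log units; that floor lies within the scatter) went at least upward, weaker inhibition is the direction expected for this new substitution too, though its size is unknown. The step of a 1.6-fold higher number from compound 1 to compound 4 (0.20 log units; within the scatter) is expected accordingly. Compound 4 is estimated at 30000 nM, within a range of 9000 nM to 100000 nM, with a fair chance that only a limit is reported.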

Compound 4, half-maximal inhibitory concentration: > 30000 nM
Compound 4 ended at the assay's limit; the forecaster's own chance of this, stated with the estimate: 55%; the middle value sits exactly at the limit.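

On this aromatic carbon, meta to a large group, benzyl brings a new kind of change to compound 1, with 7 heavy atoms and a six-membered aromatic ring of carbon only, and the result is an at least 1.5-fold higher number from compound 1 to compound 4 (0.19 log units; that floor lies within the scatter). This extra ring therefore gives compound 4 no stronger inhibition than compound 1 has. How much weaker compound 4 may be cannot be read, because the step meets a cap: the limit of > 30000 nM in this assay, at which 3 of the 4 values shown sit.

The compounds shown leave open whether an amine or a carboxylic acid on this same carbon would give a lower number than compound 1.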